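Anilino in place of methoxy on compound 1

The compounds below may be only part of what the source reports. "The series", "measured", "known", "first", "only" and "open" are said of these compounds alone.

Compound 1 (`C=C[C@@](C)(/C=C/c1ccc(OC)cc1)CCC=C(C)C`) gives > 43400 nM in a functional assay on NALM-6 cells (Homo sapiens) for cytotoxicity, with a stated time of 72 h (a higher number here means that more compound is needed for the effect, a lower number that less compound is needed), as a limit of the assay and not a number. Compound 3 (`CCOC(=O)/C(C)=C/c1cc(/C=C/[C@](C)(/C=C/c2ccc(OC)cc2)CCC=C(C)C)ccc1O`) gives > 43400 nM in this assay as a limit as well. Compound 2 (`C=C[C@@](C)(/C=C/c1ccc(O)c(C=O)c1)CCC=C(C)C`) gives a measured number of 11200 nM in this assay for its part. Compound 1 therefore offers no number to start from (the limit of > 43400 nM in this assay, at which 2 of the 3 values shown sit) and can only be read as a limit.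

Compound 4 (`C=C[C@@](C)(/C=C/c1ccc(Nc2ccccc2)cc1)CCC=C(C)C`) carries anilino in place of methoxy on an aromatic carbon, para to a large group (anilino in place of methoxy on an aromatic carbon) on the shared core. Going by the values given here, no measured step shows what such a change does. Among the compounds with values here, because compound 2 gives 11200 nM as the only number in hand, a moderate step towards less compound needed is expected in this assay and not a large one. Compound 4 may yet report only a limit. The expected change runs an at least 2.1-fold lower number from compound 1 to compound 4 (0.33 log units; beyond the scatter) by this estimate. For compound 4 the estimated value is 20000 nM with an expected range from 7000 nM to 43400 nM around it.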

Compound 4, half-maximal effective concentration: > 43400 nM
Compound 4 was reported as a limit (the forecaster's own chance of this, stated with the estimate: 45%); middle value at least 2.1-fold (0.33 log units) from the limit.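

Compound 1 and compound 4 both report only a limit in this assay, so no step between them can be read: the limit of > 43400 nM in this assay, at which 3 of the 4 values shown sit.

In this assay the compounds shown leave open what anilino in place of methoxy on an aromatic carbon does to the half-maximal effective concentration.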